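Fluorine for Hydroxyl on an Arylidene Thiazolidinone

The compounds below may be only part of what the source reports. "The series", "measured", "known", "first", "only" and "open" are said of these compounds alone.

The shared core of compound 1 `Cc1ccc(-c2cc(/N=C3/NC(=O)CS3)cs2)cc1` carries no arylidene arm, and in a functional assay on HCT-116 cells (Homo sapiens) for cytotoxicity, read by MTT assay, with a stated time of 72 h (a higher number here means a weaker inhibitor, a lower number a stronger inhibitor), compound 1 reaches only the limit of > 50000 nM, a bound of the assay and not a number. This is the point the limit of > 50000 nM in this assay, at which 1 of the 3 values shown sits, at which one of the three recorded values sits. Compound 2 `O=C1N/C(=N/c2csc(-c3ccc(Cl)cc3)c2)S/C1=C\c1ccc(Br)cc1`, which adds a bromophenyl arm on the thiazolidinone, gives 3300 nM in this assay. Compound 3 `O=C1N/C(=N/c2csc(-c3ccc(Cl)cc3)c2)S/C1=C\c1ccc(O)cc1` differs from compound 2 in bearing a hydroxyphenyl arm, yet for compound 3 the result in this assay stands as "not determined" (no result reported), so compound 3 has no number of its own among those shown.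

Compound 4 `O=C1N/C(=N/c2csc(-c3ccc(Cl)cc3)c2)S/C1=C\c1ccc(F)cc1` is reached from compound 3 by fluoro in place of hydroxy on an aromatic carbon. Among the measured compounds shown here, with no measured step to set against this change, the size and direction of the move in this assay cannot be read from the data; the only anchor is the halogen-bearing compound 2 at 3300 nM. Compound 4 is therefore estimated to fall near 5000 nM, within a range of 1500 nM to 20000 nM.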

Compound 4, half-maximal inhibitory concentration: 7400 nM
For compound 4 the middle estimate is 1.5-fold (0.17 log units) below the measured one; low and high end bracket the measured number.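

In this assay fluoro in place of bromo on an aromatic carbon gives a 2.2-fold higher number from compound 2 to compound 4 (0.35 log units; beyond the scatter) and so shows that the number at this position responds to which halogen the arm carries, by a modest amount. The step the piece set out to read, from 4-hydroxyphenyl to 4-fluorophenyl, still cannot be read, as compound 3 has no result and the hydroxy group therefore has no number to set against fluoro. Nothing measured here accounts for the move between the two halogens.

With only bromo and fluoro to compare, the compounds shown do not tell whether chloro or iodo would fall in line with them. They also leave open how an amine, a methoxy group or a carboxylic acid in the same place would read.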